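The source may hold more compounds than are shown below. What is called first, only, known or untested is meant among the compounds shown, and "the series" means these compounds.

Compound 1 `Cc1ccc(NC2=NCCO2)cc1` and compound 2 `Cc1ccc(NC2=NCCO2)cc1C` share one core, and in a functional assay on M21 cells (Homo sapiens) for inhibition, read by sulforhodamine B assay, with a stated time of 48 h (a higher number here means a weaker inhibitor of growth, a lower number a stronger inhibitor of growth), compound 1 gives 22000 nM while compound 2 gives 5100 nM. The change between them, (methyl in place of hydrogen on an aromatic carbon), brought a 4.3-fold lower number from compound 1 to compound 2 (0.63 log units; beyond the scatter). Compound 3 `Cc1ccc(NC(=O)NC(=O)CCl)cc1` has a different core, and the difference between the two cores is not broken down here; in this assay compound 3 gives 4900 nM. Compound 4 `Cc1ccc(NC(=O)NC(=O)CCl)cc1C` carries the same kind of change on the core of compound 3, (methyl in place of hydrogen on an aromatic carbon), the place differing only in that the new methyl stands meta to a group of 8 heavy atoms rather than 6. Because the same kind of change gave a 4.3-fold lower number from compound 1 to compound 2 (0.63 log units; beyond the scatter), compound 4 is expected to show a 3.1-fold lower number from compound 3 to compound 4 (0.49 log units; beyond the scatter) in this assay, resting on that single earlier step. The estimate for compound 4 is 1600 nM, expected to fall between 600 nM and 4500 nM.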

Compound 4, concentration for 50% growth inhibition: 4300 nM
Estimate against measurement, compound 4: 2.7-fold (0.43 log units) below, within the range that was stated.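

In this assay, methyl in place of hydrogen on an aromatic carbon gave a 1.1-fold lower number from compound 3 to compound 4 (0.06 log units; within the scatter), so the step seen on the core of compound 1 did not carry over in size to the core of compound 3: the same change on two cores in this assay, a 4.3-fold lower number (0.63 log units; beyond the scatter) from compound 1 to compound 2 and a 1.1-fold lower number (0.06 log units; within the scatter) from compound 3 to compound 4, 3.8-fold (0.58 log units) apart, beyond the scatter of two such steps. For these two pairs, then, the step on one core did not predict the step on the other. This does not show what sets the two steps apart, as the cores differ and the new methyl also stands meta to a group of a different size, and two pairs give no rule for any further core.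

As far as these compounds go, whether an ethyl group or a methoxy group in place of the new methyl would follow the step on the core of compound 1 or the step on the core of compound 3 remains open. So does the response of either core to an amine or a carboxylic acid on the same aromatic carbon.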